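Replacing the side group of compound 2

The source may hold more compounds than are shown below. What is called first, only, known or untested is meant among the compounds shown, and "the series" means these compounds.

Compound 1 `COc1ccc(C2CC(c3ccc4ccccc4c3)=NN2C2SC(=O)N(CC(=O)Nc3ccc(C)cc3)C2=O)cc1` and compound 2 `Cc1ccc(NC(=O)CN2C(=O)SC(N3N=C(c4ccc5ccccc5c4)CC3c3ccc(Cl)cc3)C2=O)cc1` share most of their structure. In an ADME assay on MDCK cells (Canis lupus familiaris) for cytotoxicity (a higher number here means that more compound is tolerated, a lower number that less compound is tolerated), compound 1 gives > 74300 nM as a limit of the assay and not as a number. Compound 2 likewise gives > 13300 nM as a limit only, so it has no exact position. Among the compounds with values here, the one measured step that the two limits leave unreadable from compound 1 to compound 2 puts chloro in place of methoxy on an aromatic carbon, and its size cannot be read. Compound 3 `CCN1CCN(CN2C(=O)SC(N3N=C(c4ccc5ccccc5c4)CC3c3ccc(Cl)cc3)C2=O)CC1` differs from compound 2 in one place. The change 4-ethylpiperazin-1-yl in place of (4-methylphenyl)carbamoyl on a saturated chain carbon bound to an amide-type nitrogen in a ring puts 4-ethylpiperazin-1-yl in place of (4-methylphenyl)carbamoyl on a saturated chain carbon bound to an amide-type nitrogen in a ring. Within the data shown here, no measured step touches that place, so this assay offers no direction, and nothing beyond the scatter is expected. The expected step that the limit leaves unreadable from compound 2 to compound 3 is accordingly small. The estimate for compound 3 is 20000 nM with an expected range from 6000 nM to 70000 nM and a real chance of another limit.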

Compound 3, half-maximal cytotoxic concentration: 2370 nM
For compound 3 the middle estimate is 8.4-fold (0.93 log units) above the measured one; the whole stated range lies above it.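

The place on a saturated chain carbon bound to an amide-type nitrogen in a ring is not a silent one in this assay: putting 4-ethylpiperazin-1-yl in place of (4-methylphenyl)carbamoyl gives an at least 5.6-fold lower number from compound 2 to compound 3 (0.74 log units; beyond the scatter) and so goes beyond the scatter. Compound 3 is also the only one of the three with an exact value and not a limit, which makes this the first readable step, while the step on the aromatic carbon cannot be read. The true size of the new step may be larger, since one end of it is not a number: the limit of > 13300 nM in this assay, at which 1 of the 3 values shown sits.

The (4-methylphenyl)carbamoyl leaves and the 4-ethylpiperazin-1-yl enters in a single step, and the two effects cannot be told apart. Also open, as far as these compounds go, is how a morpholine ring, a carboxylic acid or a longer chain would read at this place, and whether methoxy in place of chloro would matter alongside 4-ethylpiperazin-1-yl.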